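Replacing methylsulfonyl with pyrrolidin-1-yl on a shared core

The source may report more compounds than this note shows. Statements on the series, on what has been measured and on what is new or still open speak of the compounds shown alone.

Measured so far in a physicochemical assay for solubility, at pH 7.4; on this read-out higher numbers stand for higher solubility and lower numbers for lower solubility
Compound 1 (`CC(C)OCc1nc(Nc2ccc(C(F)(F)F)cc2)c2ccc(-c3ncccc3C(F)(F)F)cc2n1`) gives 0.04 ug/mL
Compound 2 (`O=C(O)CCc1nc(Nc2ccc(C(F)(F)F)cc2)c2ccc(-c3ncccc3C(F)(F)F)cc2n1`) gives 125 ug/mL
Compound 3 (`CS(=O)(=O)CCc1nc(Nc2ccc(C(F)(F)F)cc2)c2ccc(-c3ncccc3C(F)(F)F)cc2n1`) gives 0.2 ug/mL

Compound 3 holds the middle place of these three numbers, much closer to the bottom than to the top. Its distance from the highest number is shown by the step (a 630-fold lower number from compound 2 to compound 3 (2.80 log units; beyond the scatter)). Compound 4 (`FC(F)(F)c1ccc(Nc2nc(CN3CCCC3)nc3cc(-c4ncccc4C(F)(F)F)ccc23)cc1`) has not been measured. The change from compound 3 is pyrrolidin-1-yl in place of (methylsulfonyl)methyl on a saturated chain carbon bound to an aromatic carbon and amounts to pyrrolidin-1-yl in place of (methylsulfonyl)methyl on a saturated chain carbon bound to an aromatic carbon.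

All three measured steps altered the group at this same part of the molecule, so all bear on the question. One was modest (a 5.0-fold higher number from compound 1 to compound 3 (0.70 log units; beyond the scatter)) and the other large (a 3100-fold higher number from compound 1 to compound 2 (3.49 log units; beyond the scatter)). That large rise came with a carboxy group, which compound 4 lacks. Among the measured compounds shown here, no measured compound carries pyrrolidin-1-yl, so the direction remains a judgement and the range must stay wide. A modest rise is expected in this assay, estimated as a 7.5-fold higher number from compound 3 to compound 4 (0.88 log units; beyond the scatter) for this change. Compound 4 is expected near 1.5 ug/mL on this estimate, within an estimated range of 0.15 ug/mL to 20 ug/mL in all likelihood.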

Compound 4, solubility: 25 ug/mL
Estimate against measurement, compound 4: 17-fold (1.22 log units) below; the measured number lies above the stated range.
By their numbers in this assay, from the lowest: compound 1; then compound 3; then compound 4; then compound 2.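

In this assay, among the compounds shown here, the only large rise at this position had so far come with the carboxy group of compound 2, yet pyrrolidin-1-yl, which has no carboxy group, also gives large steps (a 630-fold higher number from compound 1 to compound 4 (2.80 log units; beyond the scatter); a 130-fold higher number from compound 3 to compound 4 (2.10 log units; beyond the scatter)). Among these compounds, then, a carboxy group is not the only change on this saturated chain carbon that goes with a large rise, and the outcome depends strongly on which group is chosen here. Compound 2 still holds the highest number, but the step down from it is only modest (a 5.0-fold lower number from compound 2 to compound 4 (0.70 log units; beyond the scatter)) when set against the large one seen with the methylsulfonyl group (a 630-fold lower number from compound 2 to compound 3 (2.80 log units; beyond the scatter)), and no measurement shown here explains these differences.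

As far as these compounds go, it remains open whether a rise of this size belongs to the pyrrolidin-1-yl ring in particular or would also come with an open-chain amine such as dimethylamino, or with a morpholine ring. The result for a longer chain carrying the same pyrrolidine ring is also unknown.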